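The source may hold more compounds than are shown below. What is called first, only, known or untested is meant among the compounds shown, and "the series" means these compounds.

Measured in a functional assay on the whole organism (trachea) for inhibition, with Cavia porcellus as the target; on this read-out higher numbers stand for an effect only at larger amounts of compound and lower numbers for an effect already at smaller amounts:
compound 1 `COc1ccccc1OCC1SCCN1C(=O)CSC`: 21 mg/kg
compound 2 `COc1ccccc1OCC1SCCN1C(=O)C[S+](C)[O-]`: 10 mg/kg
compound 3 `COc1ccccc1OCC1SCCN1C(=O)C(C)(C)C`: 24 mg/kg

Compound 3 shows 24 mg/kg and sits at the upper end of this small set, level with its closest neighbour: a 1.1-fold higher number from compound 1 to compound 3 (0.06 log units; within the scatter). The gap on the other side is a 2.4-fold higher number from compound 2 to compound 3 (0.38 log units; beyond the scatter). Compound 4 `CCOC(=O)C(C)(C)C(=O)N1CCSC1COc1ccccc1OC` differs from compound 3 by ethoxycarbonyl in place of methyl on a saturated chain carbon bound to a carbonyl carbon and two saturated chain carbons, so that tert-butyl becomes 1-(ethoxycarbonyl)-1-methylethyl. Among the compounds with values here, no measured step makes this exact change. The nearest steps alter the same side of the carbonyl carbon, and none exceeds a modest size. Only compound 2, whose side chain also holds oxygen, hints at a direction: a 2.1-fold lower number from compound 1 to compound 2 (0.32 log units; beyond the scatter). The expected change is therefore small, namely a 1.5-fold lower number from compound 3 to compound 4 (0.18 log units; within the scatter). For compound 4 the estimate is 16 mg/kg, within a range of 6 mg/kg to 40 mg/kg.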

Compound 4, dose for half-maximal effect: 48 mg/kg
Estimate against measurement, compound 4: 3.0-fold (0.48 log units) below, and the stated range ends below it.
By their numbers in this assay, from the lowest: compound 2; then compounds 1, 3 and 4 (each within the scatter of the next, the first and the last beyond it).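

In this assay, ethoxycarbonyl in place of methyl on a saturated chain carbon bound to a carbonyl carbon and two saturated chain carbons gives a 2.0-fold higher number from compound 3 to compound 4 (0.30 log units; within the scatter), so this larger group leaves the number within the scatter of tert-butyl. Oxygen in the side chain does not go with a lower number in every case: a 4.8-fold higher number from compound 2 to compound 4 (0.68 log units; beyond the scatter) and a 2.3-fold higher number from compound 1 to compound 4 (0.36 log units; beyond the scatter) both run upward, although compound 2 and compound 4 each hold oxygen there. Nothing available explains these differences. The compounds shown leave open how a carboxylic acid, an amine or a longer chain in place of ethoxycarbonyl would read.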